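This account rests on a few compounds, and the source may have more. Where it says the series, first, only, none or still open, it means among the compounds named here.

Among the measured compounds shown here, in an ADME assay on BCBL1 cells (Homo sapiens) for cytotoxicity, with a stated time of 7 days (a lower number here means that less compound is tolerated, a higher number that more compound is tolerated), compound 3 `Nc1nc(NCc2ccccc2)c2ncn(/C=C3/CC3(CO)CO)c2n1` gives 19900 nM, the only actual number among the measured compounds. Compound 1 `CCOc1nc(N)nc2c1ncn2/C=C1/CC1(CO)CO` reports only a limit, > 20000 nM. Compound 2 `CCCCCCCCOc1nc(N)nc2c1ncn2/C=C1/CC1(CO)CO` also reports only a limit, > 20000 nM. This is the limit of > 20000 nM in this assay, at which 2 of the 3 values shown sit. Compound 4 `Nc1nc(N2CCCC2)c2ncn(/C=C3/CC3(CO)CO)c2n1` differs from compound 3 by one change: pyrrolidin-1-yl in place of benzylamino on an aromatic carbon. For the measured compounds named here, the steps that bear on it also change the group on an aromatic carbon, a number no higher from compound 1 to compound 3 (the limit leaves the size open) and a number no higher from compound 2 to compound 3 (the limit leaves the size open), but neither has a readable size. The other measured step, a step that the two limits leave unreadable from compound 1 to compound 2, gives no size either. No shift beyond the scatter is therefore expected in this assay, starting from compound 3 at 19900 nM. The expected change is a 1.0-fold higher number from compound 3 to compound 4 (0.00 log units; within the scatter). Compound 4 is estimated at 20000 nM, within a range of 8000 nM to 45000 nM.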

Compound 4, half-maximal cytotoxic concentration: > 20000 nM
Compound 4: a limit, no number (the forecaster's own chance of this, stated with the estimate: 65%); the middle value lies on the limit itself.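

In this assay, pyrrolidin-1-yl in place of benzylamino on this aromatic carbon gives a number no lower from compound 3 to compound 4 (the limit leaves the size open). Compound 4 shows that a nitrogen-linked group at this position, now a five-membered non-aromatic ring without the aromatic ring of benzylamino, also leaves the read-out at a limit: the limit of > 20000 nM in this assay, at which 3 of the 4 values shown sit. The steps to compound 4 from compound 1 and from compound 2 cannot be read, as both ends are limits. As far as these compounds go, the true sizes of these steps stay open. So does whether morpholine or a longer alkylamine at this position would give a number rather than a limit.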